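This account rests on a few compounds, and the source may have more. Where it says the series, first, only, none or still open, it means among the compounds named here.

In a toxicity assay on L02 cells (Homo sapiens) for cytotoxicity, read by CCK-8 assay, with a stated time of 72 h (on this read-out lower numbers stand for stronger inhibition and higher numbers for weaker inhibition), compound 1 `CCOC(=O)/C=C1/C(=O)Nc2ccccc21` gives 4230 nM.
In this assay, compound 2 `CC(C)(C)OC(=O)/C=C1/C(=O)Nc2ccccc21` gives 2450 nM.
In this assay, compound 3 `CN1C(=O)/C(=C/C(=O)OC(C)(C)C)c2ccccc21` gives 4320 nM.

Compound 2 has the lowest of these three numbers, yet every neighbour sits within the scatter: the step of a 1.7-fold lower number from compound 1 to compound 2 (0.24 log units; within the scatter) and the step of a 1.8-fold higher number from compound 2 to compound 3 (0.25 log units; within the scatter) are both too small to count as real change. Compound 4 `CC(C)c1ccc2c(c1)/C(=C\C(=O)OC(C)(C)C)C(=O)N2` differs from compound 2 by isopropyl in place of hydrogen on an aromatic carbon. Neither measured step touches the aromatic ring, so no shown step bears directly on this change; what the measured steps do show is that two changes to the shared core left this assay unmoved beyond the scatter. The expectation is therefore a step of a 1.1-fold higher number from compound 2 to compound 4 (0.03 log units; within the scatter), with wide uncertainty. Compound 4 is estimated at 2600 nM, in the range 900 nM to 7500 nM.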

Compound 4, half-maximal inhibitory concentration: 3360 nM
Beside the measured number, compound 4's estimate is 1.3-fold (0.11 log units) below it; low and high end bracket the measured number.
By their numbers in this assay, from the lowest: compounds 2, 4, 1 and 3 (each within the scatter of the next).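

In this assay, isopropyl in place of hydrogen on an aromatic carbon gives a 1.4-fold higher number from compound 2 to compound 4 (0.14 log units; within the scatter). Among the compounds shown here, the earlier steps changed only the ester and the amide-type nitrogen, so this is the first look at the six-membered aromatic ring, and adding isopropyl at this position shifts the number no more than those changes did. Nothing measured here bears on why this is so.

As far as these compounds go, whether an amine, a carboxylic acid or a longer chain on this same aromatic carbon would also stay within the scatter remains open. So does the outcome of placing isopropyl on another carbon of this ring.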